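A few compounds are considered here, and "the series" means these few. Any claim that something is new, unique, unknown or untested is made for them only; others in the source may bear on it.

In a functional assay on MDA-MB-435 cells (Homo sapiens) for cytotoxicity, read by MTT assay, with a stated time of 48 h, tested at 20 uM (on this read-out lower numbers stand for less inhibition and higher numbers for more inhibition at the one concentration tested (going by the name of the read-out)), two compounds have been measured so far. Compound 1 `CO[C@H]1O[C@H](COc2ccc3c(c2)CCCC3)[C@@H](O)[C@H](O)[C@H]1Oc1ccc(OC2CCCCC2)cc1` gives 16% in this assay. Compound 2 `CO[C@@H]1O[C@H](COc2ccc3c(c2)CCCC3)[C@@H](O)[C@H](O)[C@H]1Oc1ccc(OC2CCCCC2)cc1` gives 1% in this assay. These two compounds share every atom and bond and differ only in how one stereocentre on the saturated ring is drawn (the fact that compounds 1 and 2 differ only in the configuration as drawn); that single change produced a number 15 percentage points lower from compound 1 to compound 2 (beyond the scatter). Among the compounds with values here, compound 2 therefore stands at the lower of the two numbers seen, with compound 1 as its only neighbour.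

Compound 3 `CO[C@@H]1O[C@H](COc2ccc(-c3ccccc3)cc2)[C@@H](O)[C@H](O)[C@H]1Oc1ccc(OC2CCCCC2)cc1` is the next compound to be measured. Compared with compound 2, the change is 4-phenylphenyl in place of 1,2,3,4-tetrahydronaphthalen-6-yl on an oxygen on a saturated carbon. Within the data shown here, the only measured step so far concerns a stereocentre and leaves this oxygen-linked group untouched, so it offers no direct guide to swapping the 1,2,3,4-tetrahydronaphthalen-6-yl group for a 4-phenylphenyl group. Among the measured compounds shown here, with no bearing step to lean on, the expected change from compound 2 to compound 3 in this assay is a number 7 percentage points higher from compound 2 to compound 3 (within the scatter), a step not beyond the usual scatter. Compound 3 is therefore estimated to give 8% in this assay, within a range from 0% to 28%.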

Compound 3, a percentage reported as inhibition, at one concentration (the size of the read-out at that concentration, not a potency): 30%
Compound 3: the middle estimate sits 22 percentage points below what was measured; the measured number lies above the stated range.
By their numbers in this assay, from the lowest: compound 2; then compound 1; then compound 3.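

In this assay, the group on an oxygen on a saturated carbon proves to matter in its own right: 4-phenylphenyl in place of 1,2,3,4-tetrahydronaphthalen-6-yl gives a number 29 percentage points higher from compound 2 to compound 3 (beyond the scatter), whereas the earlier step spoke only of a stereocentre. The swap is not a single clean difference, since a second six-membered aromatic ring replaces a non-aromatic one and the group gains heavy atoms, while neither group has hydrogen-bond donors or acceptors or a net charge. Nothing given here explains this rise, so it stands as an observation.

The compounds shown cannot say whether the higher number follows the second aromatic ring, the added heavy atoms or the overall shape of the group, and a naphthalen-2-yl group or a biphenyl carrying an amine would be natural probes of that question. On these data alone, it also remains open whether 4-phenylphenyl responds to the stereocentre as the 1,2,3,4-tetrahydronaphthalen-6-yl pair does, and, with only one concentration read, how these numbers relate to potency.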